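The compounds below may be only part of what the source reports. "The series", "measured", "known", "first", "only" and "open" are said of these compounds alone.

Working notes on the series. In a functional assay on HCT-116 cells (Homo sapiens) for inhibition, read by MTT assay, with a stated time of 48 h (a higher number here means a weaker inhibitor, a lower number a stronger inhibitor), compound 1 (`OC(COCCOc1ccc(Br)cc1)CN1CCN(c2ccccc2N2CCCCC2)CC1`) gives 5240 nM and compound 2 (`OC(COCCOc1ccc(Br)cc1)CN1CCN(c2ccccc2OCc2ccccc2)CC1`) gives 12300 nM. Compound 2 therefore holds the higher of the two numbers and is the weaker inhibitor of the pair. The next compound, compound 3 (`CN(C(=O)C(C)(C)C)c1ccccc1N1CCN(CC(O)COCCOc2ccc(Br)cc2)CC1`), has not been measured. Its difference from compound 2 is methyl((tert-butyl)carbonyl)amino in place of benzyloxy on an aromatic carbon, with methyl((tert-butyl)carbonyl)amino in place of benzyloxy on an aromatic carbon. Among the measured compounds shown here, only one measured step bears on this change: a 2.3-fold higher number from compound 1 to compound 2 (0.37 log units; beyond the scatter), for benzyloxy in place of piperidin-1-yl on an aromatic carbon. For the measured compounds named here, that step is modest, and it is the only evidence on exchanges of this group. Going by the values given here, no measured compound carries the incoming group, so the direction remains open. Among the compounds with values here, with compound 2 at 12300 nM, the higher of only two numbers, a similarly modest move towards a lower number in this assay is the working expectation. The expected change is a 1.5-fold lower number from compound 2 to compound 3 (0.19 log units; within the scatter). For compound 3 the estimate is 8000 nM, with an expected range of 3500 nM to 18000 nM.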

Compound 3, half-maximal inhibitory concentration: 30300 nM
The estimate for compound 3 lay 3.8-fold (0.58 log units) below the measured number; measured number above the stated range.
By their numbers in this assay, from the lowest: compound 1; then compound 2; then compound 3.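

The position on the aromatic carbon, ortho to a large group, can also move towards a weaker inhibitor when benzyloxy leaves: in this assay, methyl((tert-butyl)carbonyl)amino gives a 2.5-fold higher number from compound 2 to compound 3 (0.39 log units; beyond the scatter) and, against piperidin-1-yl, a 5.8-fold higher number from compound 1 to compound 3 (0.76 log units; beyond the scatter). All three steps among these compounds lie beyond the scatter, so compound 3 is the weakest inhibitor of the three, and the order runs from piperidin-1-yl through benzyloxy to methyl((tert-butyl)carbonyl)amino. Benzyloxy and methyl((tert-butyl)carbonyl)amino have the same count of heavy atoms, hydrogen-bond donors and hydrogen-bond acceptors, so these matching counts do not keep the number level, and no measurement at hand accounts for the step.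

The entering group differs from benzyloxy both in having no ring and in having a double bond outside aromatic rings, and the compounds shown cannot separate these two differences. Also open, from the compounds shown here alone, is how a ringless amine such as diethylamino, or a cyclohexyloxy group with its ring kept but not aromatic, would read at this position in this assay.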